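The source may report more compounds than this note shows. Statements on the series, on what has been measured and on what is new or still open speak of the compounds shown alone.

Compound 1 (`CCOC(=O)CCCCCOc1cccc(CN(C(=O)c2ccc(-c3cccnc3)cc2)C(C)C)c1`) was examined in an ADME assay on BJ cells (Homo sapiens) for cytotoxicity, read by CellTiter-Glo and resazurin assay, with a stated time of 72 h (on this read-out lower numbers stand for an effect already at smaller amounts and higher numbers for an effect only at larger amounts of compound), and returned only a limit of the assay, > 26000 nM, rather than a number. Compound 2 (`CCOC(=O)CCCCCOc1cccc(CN(C(=O)c2ccc(-c3cccc(OCc4ccccc4)c3)cc2)C(C)C)c1`) likewise gave no number in this assay but only the limit > 26000 nM. Within the data shown here, both compounds therefore sit at the limit of > 26000 nM in this assay, at which 2 of the 2 values shown sit, so compound 1 stands at the same limit as the only other measured compound, with no ordering between them. Compound 3 (`CCOC(=O)CCCCCOc1cccc(CN(C(=O)c2ccc(-c3ccc4cc[nH]c4c3)cc2)C(C)C)c1`) has not yet been measured in this assay; it differs from compound 1 by 1H-indol-6-yl in place of pyridin-3-yl on an aromatic carbon. Because the two values shown both rest at the limit (the limit of > 26000 nM in this assay, at which 2 of the 2 values shown sit), no step beyond the usual scatter is expected in this assay for this change. Compound 3 is therefore expected to give about 30000 nM, within 15000 nM to 80000 nM, most likely again as a limit. The expected step is a step that the limit leaves unreadable from compound 1 to compound 3.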

Compound 3, half-maximal effective concentration: > 26000 nM
Compound 3 was reported as a limit (the forecaster's own chance of this, stated with the estimate: 80%); the middle value is on the limit's open side.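

No step can be read between compound 1 and compound 3 in this assay, since each gave only a limit of the assay: the limit of > 26000 nM in this assay, at which 3 of the 3 values shown sit. The compounds shown leave open at what concentration, if any, any of them affects these cells, and whether pyridin-3-yl and 1H-indol-6-yl differ on this read-out.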